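A few compounds are considered here, and "the series" means these few. Any claim that something is new, unique, unknown or untested is made for them only; others in the source may bear on it.

Measured so far in a physicochemical assay for pharmacokinetics, at pH 4; on this read-out higher numbers stand for a longer-lived compound and lower numbers for a shorter-lived compound:
- compound 1 `COc1ccc2cc(C(C)C(=O)OCC(OC(C)=O)C(OC(C)=O)C(OC(C)=O)C(/C=N/CC(=O)O)OC(C)=O)ccc2c1`: 44 h
- compound 2 `COc1ccc2cc(C(C)C(=O)OCC(OC(C)=O)C(OC(C)=O)C(OC(C)=O)C(/C=N/[C@@H](C)C(=O)O)OC(C)=O)ccc2c1`: 15 h

For the measured compounds named here, compound 2 stands at the low end of the two numbers so far; the nearest is compound 1, and the single step of a 2.9-fold lower number from compound 1 to compound 2 (0.47 log units; beyond the scatter) is the only one recorded for the series.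

Compound 3 `COc1ccc2cc(C(C)C(=O)OCC(OC(C)=O)C(OC(C)=O)C(OC(C)=O)C(/C=N/[C@H](C(=O)O)C(C)C)OC(C)=O)ccc2c1` is the next member. The change from compound 2 is isopropyl in place of methyl on a saturated chain carbon bound to a carbonyl carbon and a double-bonded nitrogen. Put another way, 1-carboxyethyl becomes 1-carboxy-2-methylpropyl.

Going by the values given here, the only step that bears on this is a 2.9-fold lower number from compound 1 to compound 2 (0.47 log units; beyond the scatter), where a larger group entered at the same saturated chain carbon and this assay fell by a modest amount. Adding further bulk at the same place might be expected to continue in the same direction, but on one step alone the expected size is uncertain and could fall within the scatter. For compound 3 the expected step is a 1.5-fold lower number from compound 2 to compound 3 (0.18 log units; within the scatter). Compound 3 is therefore estimated at 10 h, with a range from 4 h to 30 h.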

Compound 3, half-life: 115 h
Beside the measured number, compound 3's estimate is 12-fold (1.06 log units) below it; the measured number lies above the stated range.
By their numbers in this assay, from the lowest: compound 2; then compound 1; then compound 3.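

At the saturated chain carbon bound to a carbonyl carbon and a double-bonded nitrogen, the read-out in this assay does not move in one direction as the group grows: methyl lowered the number, whereas isopropyl gives a 7.7-fold higher number from compound 2 to compound 3 (0.88 log units; beyond the scatter) and more than reverses that fall. Isopropyl also stands clear of hydrogen, with a 2.6-fold higher number from compound 1 to compound 3 (0.42 log units; beyond the scatter), so the order runs hydrogen between methyl and isopropyl rather than following the size of the group. No measurement on hand accounts for this reversal.

On these data alone, with only hydrogen, methyl and isopropyl at this carbon, it stays open whether an ethyl group or a longer unbranched chain would fall with methyl or with isopropyl. Also open, as far as these compounds go, is how a cyclopropyl ring or a tert-butyl group would read here.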